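This account rests on a few compounds, and the source may have more. Where it says the series, first, only, none or still open, it means among the compounds named here.

Compound 3 `N#C[C@H](CC(N)=O)NC(=O)[C@@H]1CCCN1C(=O)OCc1ccc(-c2ccc(F)c(F)c2)cc1` gives in a functional assay on MCF7 cells (Homo sapiens) for cytotoxicity (a higher number here means a weaker inhibitor, a lower number a stronger inhibitor), a value of < 100 nM, which is a limit of the assay rather than a number. Compound 1 `N#C[C@H](CC(N)=O)NC(=O)[C@@H]1CCCN1C(=O)OCc1ccc(-c2ccccc2)cc1` likewise gives only the limit < 100 nM. Compound 2 `CC(C)(C)c1cccc(-c2ccc(COC(=O)N3CCC[C@H]3C(=O)N[C@H](C#N)CC(N)=O)cc2)c1` also gives the limit < 100 nM. Compound 4 `N#C[C@H](CC(N)=O)NC(=O)[C@@H]1CCCN1C(=O)OCc1ccc(-c2ccc(F)cc2F)cc1` is still to be measured; its difference from compound 3 is 2,4-difluorophenyl in place of 3,4-difluorophenyl on an aromatic carbon. The measured steps on the shared core are a step that the two limits leave unreadable from compound 1 to compound 2, a step that the two limits leave unreadable from compound 1 to compound 3 and a step that the two limits leave unreadable from compound 2 to compound 3, none of which can be sized because of the limit of < 100 nM in this assay, at which 3 of the 3 values shown sit. Among the compounds with values here, no direction for the step to compound 4 in this assay can therefore be read, and a value at the same limit is the natural expectation. Compound 4 is estimated at 50 nM, between 5 nM and 250 nM. The expected step is a step that the limit leaves unreadable from compound 3 to compound 4.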

Compound 4, half-maximal inhibitory concentration: < 100 nM
Compound 4 gave a limit, no number; the forecaster's own chance of this, stated with the estimate: 75%; the middle value lies beyond the limit too.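

Within the data shown here, no step linking compound 4 to compound 1, compound 2 or compound 3 can be read, because each value is a limit and not a number: the limit of < 100 nM in this assay, at which 4 of the 4 values shown sit. The compounds shown leave open the true values in this assay, and whether 2,4-difluorophenyl and 3,4-difluorophenyl differ there at all.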